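The source may hold more compounds than are shown below. What is called first, only, known or untested is meant among the compounds shown, and "the series" means these compounds.

Compound 1, `Cc1cc(C#N)cc(C)c1Oc1ccnc(Nc2ccc(CN3CCN(S(=O)(=O)N(C)C)CC3)cc2)n1`, is the starting point. In an ADME assay on MT4 cells (Homo sapiens) for cytotoxicity, read by MTT assay (a lower number here means that less compound is tolerated, a higher number that more compound is tolerated), compound 1 gives 4460 nM, a number that cannot be told apart from its neighbours: compound 2, `Cc1cc(/C=C/C#N)cc(C)c1Oc1ccnc(Nc2ccc(CN3CCCN(S(=O)(=O)C(C)C)CC3)cc2)n1`, gives 4640 nM, and compound 3, `Cc1cc(/C=C/C#N)cc(C)c1Oc1ccnc(Nc2ccc(CN3CCCN(S(=O)(=O)N(C)C)CC3)cc2)n1`, gives 3900 nM, both within the usual scatter of compound 1. Compound 4, `CCS(=O)(=O)N1CCN(Cc2ccc(Nc3nccc(Oc4c(C)cc(C#N)cc4C)n3)cc2)CC1`, has not yet been measured; it differs from compound 1 by ethyl in place of dimethylamino on a sulfonyl sulfur. Within the data shown here, the only measured step touching that sulfonyl sulfur is a 1.2-fold lower number from compound 2 to compound 3 (0.08 log units; within the scatter), and it stayed inside the scatter. On that basis compound 4 is expected to stay close to compound 1, with no step beyond the scatter: a 1.0-fold lower number from compound 1 to compound 4 (0.01 log units; within the scatter). The estimate for compound 4 in this assay is 4400 nM, between 2400 nM and 8000 nM.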

Compound 4, half-maximal cytotoxic concentration: 5240 nM
Compound 4: the middle estimate sits 1.2-fold (0.08 log units) below what was measured, and the stated range covers the measured number.
By their numbers in this assay, from the lowest: compounds 3, 1, 2 and 4 (each within the scatter of the next).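

Replacing dimethylamino with ethyl on a sulfonyl sulfur gives a 1.2-fold higher number from compound 1 to compound 4 (0.07 log units; within the scatter) in this assay and so leaves the number within the scatter. Among these compounds, the only earlier step at this sulfur, a 1.2-fold lower number from compound 2 to compound 3 (0.08 log units; within the scatter), compared isopropyl with dimethylamino on a different core, so two separate pairs now show no readable change. No supporting measurement is available to explain this result. Still open, as far as these compounds go, is whether a phenyl ring, a longer chain or an amine on this sulfur would shift the number beyond the scatter.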